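Chalcone amides: tolerance of Vero cells, chlorophenyl variant

This account rests on a few compounds, and the source may have more. Where it says the series, first, only, none or still open, it means among the compounds named here.

Values in an ADME assay on Vero cells (Chlorocebus sabaeus) for cytotoxicity, read by MTT assay, with a stated time of 72 h (a lower number here means that less compound is tolerated, a higher number that more compound is tolerated), so far:
- compound 1 `COC(=O)c1cc(-c2cccc(NC(=O)c3ccc(C4OC4C(=O)c4ccc(Cl)cc4)cc3)c2)on1` gives > 20 ug/mL, a limit of the assay.
- compound 2 `COC(=O)c1cc(-c2cccc(NC(=O)c3ccc(/C=C/C(=O)c4cc(F)ccc4F)cc3)c2)on1` gives > 40 ug/mL, also a limit.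
- compound 3 `COC(=O)c1cc(-c2cccc(NC(=O)c3ccc(/C=C/C(=O)c4ccc(OC)cc4)cc3)c2)on1` gives > 10 ug/mL, again a limit.

Compound 2 therefore stands only at a limit, and the two other values shown are limits as well (the limit of > 10 ug/mL in this assay, at which 1 of the 3 values shown sits, (the limit of > 20 ug/mL in this assay, at which 1 of the 3 values shown sits), (the limit of > 40 ug/mL in this assay, at which 1 of the 3 values shown sits)). The next compound is compound 4 `COC(=O)c1cc(-c2cccc(NC(=O)c3ccc(/C=C/C(=O)c4ccc(Cl)cc4)cc3)c2)on1`, with 4-chlorophenyl in place of 2,5-difluorophenyl on a carbonyl carbon. The step at the same place, a step that the two limits leave unreadable from compound 2 to compound 3, and the step that the two limits leave unreadable from compound 1 to compound 2 both stay unreadable between limits, so no size or direction can be taken from them for this assay. Compound 4 is expected to sit at or near a limit again, giving an estimated a number no higher from compound 2 to compound 4 (the limit leaves the size open), with compound 4 expected at 40 ug/mL (range 15 ug/mL to 100 ug/mL).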

Compound 4, half-maximal cytotoxic concentration: > 50 ug/mL
Compound 4 gave a limit, no number (the forecaster's own chance of this, stated with the estimate: 80%); middle value at least 1.2-fold (0.09 log units) from the limit.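

In this assay compound 4 gives > 50 ug/mL, a limit of the assay. Its steps to compound 1, compound 2 and compound 3 stay unreadable, all being between limits. The compounds shown leave open where any actual half-maximal cytotoxic concentration lies.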